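The source may report more compounds than this note shows. Statements on the series, on what has been measured and on what is new or still open speak of the compounds shown alone.

Measured in a physicochemical assay for lipophilicity, read by HPLC, at pH 7.4; on this read-out lower numbers stand for lower lipophilicity and higher numbers for higher lipophilicity:
- compound 1 `CCC/N=C1\S/C(=C\c2ccc(O)c(Cl)c2)C(=O)N1C1CCS(=O)(=O)CC1`: 2.6
- compound 2 `CCC/N=C1\S/C(=C\c2ccc(O)cc2)C(=O)N1c1ccccc1C`: 3.5
- compound 3 `Cc1ccccc1N1C(=O)/C(=C/c2ccc(O)c(Cl)c2)S/C1=N\CCO`: 1.9

Compound 1 stands in the middle of these three numbers. Compound 3 lies lower and compound 2 lies higher, and both gaps are larger than the scatter normally seen between repeated measurements. Each pair differs in more than one place, however, so none of them shows what a single change does.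

The next compound to be measured is compound 4 `CCC/N=C1\S/C(=C\c2ccc(O)c(Cl)c2)C(=O)N1C1CCN(C)C(=O)C1`, which keeps the core of compound 1 and changes one group: 1-methyl-2-oxopiperidin-4-yl in place of 1,1-dioxothian-4-yl on an amide-type nitrogen in a ring. In words, 1-methyl-2-oxopiperidin-4-yl takes the place of 1,1-dioxothian-4-yl on an amide-type nitrogen in a ring. Both groups are six-membered non-aromatic rings with no net charge.

Among the measured compounds shown here, no measured pair tests this swap, so the expectation is a judgement from the structures alone. With compound 1 at 2.6 as the starting point, no step beyond the scatter is expected in this assay, and neither direction is favoured with any confidence. The expected change is small: a number 0.10 log units lower from compound 1 to compound 4 (within the scatter). The estimated value for compound 4 is 2.5, within an expected range from 2 to 3.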

Compound 4, distribution coefficient: 0.6
The estimate for compound 4 lay 1.90 log units above the measured number; measured number below the stated range.
By their numbers in this assay, from the lowest: compound 4; then compound 3; then compound 1; then compound 2.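

The readings in this assay now hold their first single change: 1-methyl-2-oxopiperidin-4-yl in place of 1,1-dioxothian-4-yl on an amide-type nitrogen in a ring gives a number 2.00 log units lower from compound 1 to compound 4 (beyond the scatter) with the rest of the molecule unaltered. This place on the core is therefore far from indifferent, since two groups that each have 8 heavy atoms, one six-membered non-aromatic ring with 1 hetero atom, no hydrogen-bond donors and no net charge can still read very differently, so these shared counts alone do not settle the number. Nothing measured here accounts for the size of this step.

From the compounds shown here alone, because this is a single pair, it remains open which part of the entering group goes with the step, the ring nitrogen with its methyl or the carbonyl, and whether the same swap would give a similar step with the other substituents seen in this set. Also open, going by these compounds, is how a plain cyclohexyl ring, a piperidin-4-yl ring with its free amine, or an open 2-methoxyethyl chain would read at this place.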